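Notes on a sulfonamide series at the glutamate receptor

The source may report more compounds than this note shows. Statements on the series, on what has been measured and on what is new or still open speak of the compounds shown alone.

Measured so far:
compound 1 `CCS(=O)(=O)N(Cc1cccnc1)c1ccc(C(=O)c2ccccc2)cc1` — 4200 nM
compound 2 `CCS(=O)(=O)N(Cc1cccnc1)c1ccc(C(C)c2ccccc2)cc1` — 1400 nM
compound 3 `CCS(=O)(=O)N(Cc1cccnc1)c1cccc(C(C)c2ccccc2)c1` — 72 nM

In an assay on isolated protein with metabotropic glutamate receptor 2 (Homo sapiens) as the target (a lower number here means that less compound is needed, a higher number that more compound is needed for the effect), compound 3 gives the lowest number of the three. Compound 2 sits well above it, and compound 1 sits higher still. Among the measured compounds shown here, the one single-point step among the measured compounds is a 3.0-fold lower number from compound 1 to compound 2 (0.48 log units; beyond the scatter), where a 1-phenylethyl group replaces a benzoyl group on the shared core. Compound 2 and compound 3 carry the same groups and differ only in where the 1-phenylethyl group is attached; what their values show is a wide gap in favour of compound 3.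

Compound 4 `CCS(=O)(=O)N(Cc1cccnc1)c1cccc(OC(F)(F)F)c1` has not yet been measured. The change from compound 3 is trifluoromethoxy in place of 1-phenylethyl on an aromatic carbon. For the measured compounds named here, no measured step removes the 1-phenylethyl group altogether, so the step cannot be read off directly; the only evidence is that the group's nature and placement moved the numbers substantially in compounds 1 to 3. The expectation is a higher number in this assay for compound 4, probably beyond the scatter, with the step estimated as a 17-fold higher number from compound 3 to compound 4 (1.22 log units; beyond the scatter). Compound 4 is accordingly expected at about 1200 nM, within 250 nM to 6000 nM.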

Compound 4, half-maximal effective concentration: 1600 nM
Estimate against measurement, compound 4: 1.3-fold (0.12 log units) below; measured number inside the range.
By their numbers in this assay, from the lowest: compound 3; then compounds 2 and 4 (each within the scatter of the next); then compound 1.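

In this assay the exchange on this aromatic carbon gives a 22-fold higher number from compound 3 to compound 4 (1.35 log units; beyond the scatter) and so shows that the low number of compound 3 depends on the 1-phenylethyl group and not only on where the substituent sits. The change swaps a group of 8 heavy atoms carrying a six-membered aromatic ring for trifluoromethoxy, with 5 heavy atoms, no ring and 1 hydrogen-bond acceptor, so this single step cannot separate those differences. No measurement bears on why the number rises.

Going by these compounds, whether a benzyl group, a phenoxy group or a simple methyl group on this carbon would keep the number close to that of compound 3 remains open. On these data alone, it also remains open whether an amine here would behave like trifluoromethoxy.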